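The source may hold more compounds than are shown below. What is called first, only, known or untested is meant among the compounds shown, and "the series" means these compounds.

Measured so far:
- compound 1, `COc1cccc(-c2cc3[nH]nc(N)c3c(=O)[nH]2)c1`: 10%
- compound 2, `Cn1nc(N)c2c(=O)[nH]c(-c3ccccc3)cc21`: 11%

Both compounds were tested in an assay on isolated protein for inhibition of MAP kinase-activated protein kinase 5 (Homo sapiens), read by mobility shift assay, tested at 30 uM; on this read-out higher numbers stand for more inhibition at the one concentration tested (going by the name of the read-out) and lower numbers for less inhibition. Compound 2 gives 11%, and compound 1 gives 10%; the gap between them lies within the usual scatter of this assay, so the two numbers cannot be told apart, and neither number can be called the higher one. Both numbers are low at the single concentration tested.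

Compound 3, `COc1cccc(-c2cc3c(c(N)nn3C)c(=O)[nH]2)c1`, has not yet been measured in this assay. It differs from compound 2 in one place: methoxy in place of hydrogen on an aromatic carbon. Going by these compounds, no change of this kind has been measured on this shared core, so its effect is unknown. Since compound 1, which also carries a methoxy group, gives a number close to compound 2, no step beyond the scatter is expected in this assay. The estimate for compound 3 is 12%, within 2% to 25%, which means an expected step of a number 1 percentage points higher from compound 2 to compound 3 (within the scatter).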

Compound 3, a percentage reported as inhibition, at one concentration (the size of the read-out at that concentration, not a potency): 6%
The estimate for compound 3 lay 6 percentage points above the measured number; the measured number falls inside the stated range.
By their numbers in this assay, from the lowest: compounds 3, 1 and 2 (each within the scatter of the next).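

In this assay, methoxy in place of hydrogen on an aromatic carbon, meta to a large group, gives a number 5 percentage points lower from compound 2 to compound 3 (within the scatter). This gives the change a measured step on the shared core, and that step cannot be told apart from repeat-to-repeat variation. Methyl in place of hydrogen on an aromatic nitrogen gives a number 4 percentage points lower from compound 1 to compound 3 (within the scatter), so neither change separates the compounds, and no measurement here offers an explanation for either step.

All three compounds give low numbers at the single concentration tested, so these data do not show whether either place can affect inhibition. Going by these compounds, it remains open whether an amine or a carboxylic acid on the aromatic ring, or a longer chain in place of methyl on the nitrogen, would give a step beyond the scatter.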